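Shrinking the Side Chain: From Isobutyl to Cyclopropyl

The source may report more compounds than this note shows. Statements on the series, on what has been measured and on what is new or still open speak of the compounds shown alone.

Measured so far:
Compound 1, `O=C(O)c1ccccc1-c1ccc(CCc2ncc(CCc3ccccc3)[nH]2)cc1`, gives 1320 nM in an in vitro functional assay on cells for agonist activity at Bombesin receptor subtype-3 (Homo sapiens), read by luminescence and calcium flux; on this read-out higher numbers stand for an effect only at larger amounts of compound and lower numbers for an effect already at smaller amounts.
Compound 2, `O=C(O)c1ccccc1-c1ccc(CCc2ncc(Cc3ccc(Cl)cc3)[nH]2)cc1`, gives 2290 nM in this assay.
Compound 3, `CC(C)CCc1cnc(CCc2ccc(-c3ccccc3C(=O)O)cc2)[nH]1`, gives 119 nM in this assay.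

Compound 3 shows the lowest number of the three, set apart by an 11-fold lower number from compound 1 to compound 3 (1.05 log units; beyond the scatter) and by a 19-fold lower number from compound 2 to compound 3 (1.28 log units; beyond the scatter). The unmeasured compound 4, `O=C(O)c1ccccc1-c1ccc(CCc2ncc(CC3CC3)[nH]2)cc1`, differs from compound 3 in one place: cyclopropyl in place of isobutyl on a saturated chain carbon bound to an aromatic carbon. The two steps that bear on this change are those leading to compound 3, both large and both lowering the number when a phenyl or 4-chlorophenyl gives way to an open chain. Cyclopropyl brings back a ring, but a three-membered non-aromatic ring of carbon only, and it sits in the same place as isobutyl. A small step in this assay is therefore expected, a modest rise being more likely than a fall, that is a 2.1-fold higher number from compound 3 to compound 4 (0.32 log units; beyond the scatter). Compound 4 is estimated at 250 nM, within 90 nM to 700 nM.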

Compound 4, half-maximal effective concentration: 1000 nM
Compound 4: the middle estimate sits 4.0-fold (0.60 log units) below what was measured, outside the stated range (above it).
By their numbers in this assay, from the lowest: compound 3; then compounds 4, 1 and 2 (each within the scatter of the next, the first and the last beyond it).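

Replacing isobutyl with cyclopropyl gives an 8.4-fold higher number from compound 3 to compound 4 (0.92 log units; beyond the scatter), so at this place a three-membered non-aromatic ring does not stand in for the branched chain, despite the small change in size. Compound 4 instead falls close to the compounds with aromatic rings: the comparison with compound 2 gives a 2.3-fold lower number from compound 2 to compound 4 (0.36 log units; beyond the scatter), and that with compound 1 gives a 1.3-fold lower number from compound 1 to compound 4 (0.12 log units; within the scatter), which is within the scatter. No measurement is available to explain the step from isobutyl to cyclopropyl.

The compounds shown leave open whether the ring itself or the lower carbon count matters more. A straight butyl chain or a cyclobutyl group here would help separate the two.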